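Bromine in place of the sulfonylmethyl arm

The compounds below may be only part of what the source reports. "The series", "measured", "known", "first", "only" and "open" are said of these compounds alone.

Measured so far in a functional assay on the whole organism with Rattus norvegicus as the target, with a stated time of 4 h, at a dose of 40 mg/kg by the intraperitoneal route; on this read-out higher numbers stand for more inhibition at the one dose given (going by the name of the read-out) and lower numbers for less inhibition:
compound 1, `Cc1nc2c(OCc3ccccc3)cccn2c1C[S+](C)[O-]`: 0%
compound 2, `Cc1nc2c(OCc3ccccc3)cccn2c1CS(C)(=O)=O`: 61%

Compound 2 stands highest of the two numbers; the nearest, compound 1, gives 0% in this assay, and the step of a number 61 percentage points higher from compound 1 to compound 2 (beyond the scatter) is the only one in hand. That step exchanges one group of three heavy atoms for one of four heavy atoms on the saturated chain carbon, and it says nothing about removing the chain altogether.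

Compound 3, `Cc1nc2c(OCc3ccccc3)cccn2c1Br`, is not yet measured. It differs from compound 2 by bromo in place of (methylsulfonyl)methyl on an aromatic carbon. Going by the values given here, no measured step covers a change of this kind, so the direction is open: the whole two-acceptor arm that seems to carry the inhibition of compound 2 is gone, and what a single bromine does on that carbon is unknown. The step of a number 31 percentage points lower from compound 2 to compound 3 (beyond the scatter) is therefore expected to be a drop, with a wide range around it. For compound 3 the estimate in this assay is 30%, expected to lie between 0% and 70%.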

Compound 3, a percentage reported as inhibition, in the whole organism at one dose (the size of the read-out at that dose, not a potency): 26%
Estimate against measurement, compound 3: 4 percentage points above; measured number inside the range.
By their numbers in this assay, from the lowest: compound 1; then compound 3; then compound 2.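

In this assay, bromo in place of (methylsulfonyl)methyl on this aromatic carbon of the five-membered ring gives a number 35 percentage points lower from compound 2 to compound 3 (beyond the scatter), so the read-out at this dose does not depend entirely on the sulfonyl arm, although that arm gives the highest number of the three compounds. Set against the arm of compound 1, the same single bromine gives a number 26 percentage points higher from compound 1 to compound 3 (beyond the scatter), so a group of several heavy atoms on this carbon can stand on either side of a bromine, and the sulfur-bearing arms cannot be treated as one class. Nothing at hand gives a reason for this order among the three compounds.

On these data alone, it remains open whether any group on this carbon would match the (methylsulfonyl)methyl arm, and a longer chain ending in a methylsulfonyl group, an aminomethyl group or a carboxylic acid would test whether the arm's length or its end group governs the read-out. Plain hydrogen or chlorine at the same carbon would show whether the number for compound 3 belongs to bromine itself or merely to the absence of the arm.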